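Benzoyl out, pyridin-3-yl in: expected solubility of compound 4

The compounds below may be only part of what the source reports. "The series", "measured", "known", "first", "only" and "open" are said of these compounds alone.

In a physicochemical assay for solubility, read by LC-MS, in phosphate buffer, with a stated time of 24 h, at pH 7.4 (on this read-out lower numbers stand for lower solubility and higher numbers for higher solubility), compound 3 (`CN(C(=O)c1ccccc1)c1cnc(NCc2c(F)ccc3c2CCO3)n2cnnc12`) gives 280000 nM, the highest number in the set. Compound 1 (`O=C1c2ccccc2CN1c1cnc(NCc2c(F)ccc3c2CCO3)n2cnnc12`) gives 4000 nM. Compound 2 (`CN(c1ccccc1)c1cnc(NCc2c(F)ccc3c2CCO3)n2cnnc12`) reads < 2000 nM, which is a limit of the assay and not a number.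

Compound 4 (`CN(c1cccnc1)c1cnc(NCc2c(F)ccc3c2CCO3)n2cnnc12`) carries pyridin-3-yl in place of benzoyl on a nitrogen on an aromatic ring. For the measured compounds named here, two measured steps bear on this change. Benzoyl in place of phenyl gave an at least 140-fold higher number from compound 2 to compound 3 (2.14 log units; beyond the scatter), and the other step gave a 70-fold higher number from compound 1 to compound 3 (1.85 log units; beyond the scatter). Compound 4 again has an aromatic ring on that nitrogen, so a large fall in this assay is expected, with an expected step of a 47-fold lower number from compound 3 to compound 4 (1.67 log units; beyond the scatter). The estimate for compound 4 is 6000 nM, with an expected range from 2000 nM to 40000 nM.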

Compound 4, solubility: 47000 nM
Compound 4: middle estimate off by 7.8-fold (0.89 log units), on the low side, outside the stated range (above it).
By their numbers in this assay, from the lowest: compound 1; then compound 4; then compound 3. At a limit, below all of these: compound 2.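

In this assay, an aromatic ring on this nitrogen need not leave the number low: pyridin-3-yl in place of phenyl gives an at least 23-fold higher number from compound 2 to compound 4 (1.37 log units; beyond the scatter). Compound 2 stands at a limit and not a number, so that step is only a floor: the limit of < 2000 nM in this assay, at which 1 of the 4 values shown sits. Pyridin-3-yl in place of benzoyl gives a 6.0-fold lower number from compound 3 to compound 4 (0.78 log units; beyond the scatter), and the change from the group on compound 1 gives a 12-fold higher number from compound 1 to compound 4 (1.07 log units; beyond the scatter), so benzoyl is not the only group here that reads well clear of that limit.

Open, going by these compounds, is how pyridin-4-yl or pyrimidin-5-yl on this nitrogen would read against compound 4. Also open, on these data alone, is the effect of a longer chain in place of the methyl on that nitrogen.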